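The source may hold more compounds than are shown below. What is called first, only, known or untested is meant among the compounds shown, and "the series" means these compounds.

Measured in an ADME assay on Vero cells (Chlorocebus sabaeus) for cytotoxicity; a higher number here means that more compound is tolerated, a lower number that less compound is tolerated:
- Compound 1 `O=[N+]([O-])c1ccc(-c2nc3cc(C(F)(F)F)ccc3n2C2CCCCC2)cc1`: > 100000 nM
- Compound 2 `Cn1c(-c2ccc(N)cc2)nc2cc(C(F)(F)F)ccc21`: > 100000 nM

Compound 2 reads > 100000 nM in this assay, and this value is a limit of the assay, not a number. Compound 1 reads > 100000 nM, which is also a limit. The picture so far is therefore a single one: the limit of > 100000 nM in this assay, at which 2 of the 2 values shown sit. Neither compound has shown a measurable cytotoxic concentration, and no measured step connects them.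

The next compound, compound 3 `Nc1ccc(-c2nc3cc(C(F)(F)F)ccc3n2C2CCCCC2)cc1`, is reached from compound 2 by placing cyclohexyl in place of methyl on an aromatic nitrogen. Compound 3 keeps the 4-aminophenyl group of compound 2. The cyclohexyl group is already present in compound 1, which reads > 100000 nM, so the expectation rests on that limit. No change beyond the usual scatter is expected, and no direction is favoured: the estimated step is a number no higher from compound 2 to compound 3 (the limit leaves the size open). A report of only a limit is expected to be the likeliest outcome. For compound 3 the estimated half-maximal cytotoxic concentration is 100000 nM, with an expected range from 30000 nM to 150000 nM.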

Compound 3, half-maximal cytotoxic concentration: > 100000 nM
Compound 3: only a limit was reported; the forecaster's own chance of this, stated with the estimate: 70%; the middle value sits exactly at the limit.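

Among these compounds, no step to compound 3, from either compound 1 or compound 2, can be read in this assay, because all three compounds sit at the same limit of the assay: the limit of > 100000 nM in this assay, at which 3 of the 3 values shown sit.

The compounds shown leave open at what concentration any of them becomes cytotoxic, and whether cyclohexyl in place of methyl or amino in place of nitro changes that concentration.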